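This account rests on a few compounds, and the source may have more. Where it says the series, first, only, none or still open, it means among the compounds named here.

Compound 3 `CCNC(=N)c1cnc(N2CCN(C3CCN(Cc4ccc(Cl)cc4)CC3)[C@@H](C)C2)c(Cl)c1` gives 83 nM in a functional assay for antagonist activity at C-X-C chemokine receptor type 3 (Homo sapiens) (on this read-out higher numbers stand for weaker inhibition and lower numbers for stronger inhibition), the lowest of the three numbers recorded so far. Compound 2 `CC1CN(C2CCN(Cc3ccc(Cl)cc3)CC2)CCN1c1ccc(C(=O)NCc2ccc(F)c(F)c2)cn1` gives 2700 nM in this assay. Compound 1 `CNC(=O)c1cnc(N2CCN(C3CCN(Cc4ccc[nH]4)CC3)[C@@H](C)C2)c(Cl)c1` gives 8060 nM. Both gaps from compound 3 lie beyond the scatter, so compound 3 is the strongest inhibitor among the three. Compound 4 `C[C@H]1CN(c2ncc(C(=O)Nc3ccc(F)c(F)c3)cc2Cl)CCN1C1CCN(Cc2ccc(Cl)cc2)CC1` has not yet been measured. It differs from compound 3 in one place: a group of 11 heavy atoms (7 carbon, 1 nitrogen, 1 oxygen, 2 fluorine; one six-membered aromatic ring of carbon only) in place of a group of 5 heavy atoms (3 carbon, 2 nitrogen; no ring), on an aromatic carbon. Within the data shown here, no pair of measured compounds differs in only that place, so the size of this step cannot be read off directly. Still, the two weaker compounds each carry a carbamoyl group on the shared core: compound 1 gave 8060 nM, and compound 2 gave 2700 nM, while the one strong inhibitor, compound 3, lacks such a group. On that basis the expected step is an 11-fold higher number from compound 3 to compound 4 (1.04 log units; beyond the scatter), toward weaker inhibition and beyond the scatter, though with considerable uncertainty because compound 2 gave 2700 nM with a carbamoyl group bearing a different substituent. For compound 4 the expected value in this assay is 900 nM, with a likely range from 200 nM to 4000 nM.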

Compound 4, half-maximal inhibitory concentration: 22 nM
Compound 4: middle estimate off by 41-fold (1.61 log units), on the high side; measured number below the stated range.
By their numbers in this assay, from the lowest: compound 4; then compound 3; then compound 2; then compound 1.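

In this assay, putting (3,4-difluorophenyl)carbamoyl in place of the ring-free group, on the aromatic carbon two atoms from the ring nitrogen, gives a 3.8-fold lower number from compound 3 to compound 4 (0.58 log units; beyond the scatter), a step toward stronger inhibition. This place on the shared core therefore accepts a much larger group carrying an aromatic ring, and a carbamoyl group there can go with the lowest number of the four compounds, so the weak inhibition of compound 1 and compound 2 cannot be pinned on a carbamoyl group as such; both differ from compound 4 in more than one place, and their steps to it cannot be read. Nothing available explains why the new group gives the lower number, so the step stands as an observation only.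

The compounds shown leave open which part of the new group carries the gain, since a plain phenylcarbamoyl, a monofluorophenylcarbamoyl or a simple methylcarbamoyl on this same core would each separate the fluorines, the aromatic ring and the carbonyl from one another. They also leave open whether a 3,4-difluorobenzylcarbamoyl, with its extra methylene, would keep this level of inhibition on the chloro-bearing core of compound 4.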